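From (4-methoxycyclohexyl)methyl to 4-methoxycyclohexyl on the shared core

The compounds below may be only part of what the source reports. "The series", "measured", "known", "first", "only" and "open" are said of these compounds alone.

Of the compounds shown here, two on the shared core have numbers so far in an ADME assay on S9 fraction (Rattus norvegicus) for metabolic stability, with a stated time of 60 min; a higher number here means that more of the compound is left, a lower number that less of the compound is left. Compound 1 `CC(C)(O)c1ccc(-c2cnc3c(n2)N(CC2CCOCC2)C(=O)CN3)cn1` gives 83%. Compound 2 `CO[C@H]1CC[C@@H](CN2CC(=O)Nc3ncc(-c4ccc(C(C)(C)O)nc4)nc32)CC1` gives 39%, the lower of the two numbers, and its gap to compound 1 lies beyond the scatter.

Compound 3 `CO[C@H]1CC[C@H](N2CC(=O)Nc3ncc(-c4ccc(C(C)(C)O)nc4)nc32)CC1` has not yet been measured in this assay. It carries one change from compound 2: 4-methoxycyclohexyl in place of (4-methoxycyclohexyl)methyl on a nitrogen on an aromatic ring in a ring. The group still holds a six-membered non-aromatic ring of carbon only, and the place of the change is a nitrogen in a six-membered non-aromatic ring with 2 nitrogen, part of a fused or bridged system of two rings.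

Going by the values given here, no measured pair shows this change, so the expectation is a judgement with little support. Compound 2 at 39% leaves room upward, and compound 1 at 83% shows that a much higher number occurs on the shared core. An upward step beyond the scatter is expected, estimated as a number 21 percentage points higher from compound 2 to compound 3 (beyond the scatter). For compound 3 the estimated value is 60%, with an expected range of 40% to 80%.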

Compound 3, percent of the compound remaining: 94%
For compound 3 the middle estimate is 34 percentage points below the measured one, outside the stated range (above it).
By their numbers in this assay, from the lowest: compound 2; then compound 1; then compound 3.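

In this assay the position on a nitrogen on an aromatic ring in a ring proves highly sensitive: 4-methoxycyclohexyl in place of (4-methoxycyclohexyl)methyl gives a number 55 percentage points higher from compound 2 to compound 3 (beyond the scatter) and is a large step for a group that goes only from 9 heavy atoms to 8. The low number of compound 2 does not follow from the methoxy-bearing six-membered carbon ring alone, as compound 3 carries that ring too and gives 94% with the same count of hydrogen-bond donors and acceptors in the group. Going by these compounds alone, nothing at hand explains the size of this step, so the single pair records an effect on the number without giving its origin.

The compounds shown leave open whether the high number depends on the methoxy group, and a hydroxyl or an amine on the cyclohexyl ring in its place would test this. They also leave open how the number responds to a longer chain, such as a two-carbon ethyl link to the same ring, and whether the step seen here carries over to other groups at this position.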